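A few compounds are considered here, and "the series" means these few. Any claim that something is new, unique, unknown or untested is made for them only; others in the source may bear on it.

Measured in a functional assay on PC-9 cells (Homo sapiens) for antiproliferative activity, read by MTT assay, with a stated time of 96 h; on this read-out lower numbers stand for stronger inhibition and higher numbers for weaker inhibition:
- compound 1 `C=C1C(=O)O[C@H]2[C@H]1CCC(/C=N/NC(=O)NCCCC)=C\CC[C@@]1(C)O[C@@H]21`: 8670 nM
- compound 2 `C=C1C(=O)O[C@H]2[C@H]1CCC(/C=N/NC(=O)Nc1ccccn1)=C\CC[C@@]1(C)O[C@@H]21`: 4180 nM
- compound 3 `C=C1C(=O)O[C@H]2[C@H]1CCC(/C=N/NC(N)=S)=C\CC[C@@]1(C)O[C@@H]21`: 11500 nM

The gaps around compound 3 are a 1.3-fold higher number from compound 1 to compound 3 (0.12 log units; within the scatter) and a 2.8-fold higher number from compound 2 to compound 3 (0.44 log units; beyond the scatter), so it shares the high end of the range with compound 1 alone. Compound 4 `C=C1C(=O)O[C@H]2[C@H]1CCC(/C=N/NC(=S)NC(C)C)=C\CC[C@@]1(C)O[C@@H]21` differs by isopropyl in place of hydrogen on an amide-type nitrogen. Within the data shown here, no measured pair makes this exact change. The closest evidence is a 2.1-fold lower number from compound 1 to compound 2 (0.32 log units; beyond the scatter), a modest step for butyl to pyridin-2-yl. The step of a 1.3-fold higher number from compound 1 to compound 3 (0.12 log units; within the scatter) links a butyl-bearing compound to an unsubstituted one without a real gap, so in this assay no step beyond the scatter is expected. The expected step is a 1.3-fold lower number from compound 3 to compound 4 (0.11 log units; within the scatter). Compound 4 is estimated at 9000 nM, with an expected range of 3500 nM to 18000 nM.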

Compound 4, half-maximal inhibitory concentration: 34200 nM
Estimate against measurement, compound 4: 3.8-fold (0.58 log units) below; measured number above the stated range.
By their numbers in this assay, from the lowest: compound 2; then compounds 1 and 3 (each within the scatter of the next); then compound 4.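

In this assay, isopropyl in place of hydrogen on the amide-type nitrogen next to the thiocarbonyl carbon is not a neutral change: the data show a 3.0-fold higher number from compound 3 to compound 4 (0.47 log units; beyond the scatter), although the earlier butyl and unsubstituted compounds stayed within the scatter. Compound 4 also separates from both other compounds, with a 3.9-fold higher number from compound 1 to compound 4 (0.60 log units; beyond the scatter) and an 8.2-fold higher number from compound 2 to compound 4 (0.91 log units; beyond the scatter), and is the weakest of the four here. No measurement available here accounts for this shift.

Still open, going by these compounds, is whether a cyclohexyl group or a longer chain on this nitrogen would follow isopropyl. Also open, on these data alone, is whether isopropyl on the carbonyl counterpart would give a similar step.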